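Swapping a Furan for an Oxetane on a Piperidine Amine

The compounds below may be only part of what the source reports. "The series", "measured", "known", "first", "only" and "open" are said of these compounds alone.

Measured so far in an assay on HEK293 cells for displacement of a labelled ligand from growth hormone secretagogue receptor type 1 (Homo sapiens), with a stated time of 60 min; on this read-out higher numbers stand for weaker inhibition and lower numbers for stronger inhibition:
- compound 2 `COc1cccc(-n2cc3nc(-c4cccnc4C)n(C[C@H]4CCCN(Cc5ccco5)C4)c(=O)c3n2)c1`: 2.7 nM
- compound 1 `Cc1ncccc1-c1nc2cn(-c3cccc(OC(C)C)c3)nc2c(=O)n1C[C@H]1CCCN(C[C@H]2CCCO2)C1`: 11 nM

Of the two measured compounds, compound 2 gives the lower number in this assay, and the gap to compound 1 lies beyond the usual scatter; since the two differ in several places at once, nothing more can be read from the pair. Compound 3 `COc1cccc(-n2cc3nc(-c4cccnc4C)n(C[C@H]4CCCN(CC5CCO5)C4)c(=O)c3n2)c1` differs from compound 2 in one place only: oxetan-2-yl in place of furan-2-yl on a saturated chain carbon bound to an amine nitrogen in a ring. Going by the values given here, no measured pair shows this change, so the expected step is a 3.0-fold higher number from compound 2 to compound 3 (0.47 log units; beyond the scatter), a modest move toward weaker inhibition. Compound 3 is expected to give about 8 nM, with a likely range from 2.5 nM to 25 nM.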

Compound 3, half-maximal inhibitory concentration: 23 nM
Beside the measured number, compound 3's estimate is 2.9-fold (0.46 log units) below it; the measured number falls inside the stated range.
By their numbers in this assay, from the lowest: compound 2; then compound 1; then compound 3.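

Going by these compounds alone, the step of an 8.5-fold higher number from compound 2 to compound 3 (0.93 log units; beyond the scatter) in this assay is the first reading here of a change in one place alone. With everything else held fixed, the ring on this saturated chain carbon clearly matters, and oxetan-2-yl does not preserve the inhibition seen with furan-2-yl. Nothing available explains the difference. Still open, going by these compounds, is whether a ring of carbon alone, such as phenyl or cyclobutyl, would behave more like furan-2-yl or oxetan-2-yl. It is also unknown whether the same swap would give a similar step in a compound differing elsewhere.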